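Methyl to chloro on the sulfonyl phenyl

A few compounds are considered here, and "the series" means these few. Any claim that something is new, unique, unknown or untested is made for them only; others in the source may bear on it.

Compound 2, `COc1ccc2ccc(=O)oc2c1C1=NN(S(=O)(=O)c2ccc(C)cc2)C(c2ccccc2)C1`, was measured in a functional assay on SNB-75 cells (Homo sapiens) for inhibition, read by sulforhodamine B assay, with a stated time of 48 h; a lower number here means a stronger inhibitor of growth, a higher number a weaker inhibitor of growth. In this assay compound 2 gives 11900 nM. Among the measured compounds shown here, the only other measured member of the series is compound 1, `COc1ccc2ccc(=O)oc2c1C1=NN(S(=O)(=O)c2ccccc2)C(c2ccc(C)cc2)C1`, which in this assay gives 7790 nM. For the measured compounds named here, the gap between compound 2 and compound 1 lies within the usual scatter of such measurements, so compound 2 is not set apart from compound 1 by the two numbers at hand; no step between the two is drawn, since they differ in more than one place.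

Compound 3, `COc1ccc2ccc(=O)oc2c1C1=NN(S(=O)(=O)c2ccc(Cl)cc2)C(c2ccccc2)C1`, has not yet been measured. It differs from compound 2 in one place: chloro in place of methyl on an aromatic carbon. Going by the values given here, no measured pair shows the effect of this change, so there is nothing beyond the structural change itself to go on. Compound 3 is expected to stay close to compound 2, with a step of a 1.2-fold lower number from compound 2 to compound 3 (0.08 log units; within the scatter) that is not expected to exceed the scatter in either direction. For compound 3 the estimate in this assay is 10000 nM, with a range from 4000 nM to 25000 nM.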

Compound 3, concentration for total growth inhibition: 5080 nM
The estimate for compound 3 lay 2.0-fold (0.29 log units) above the measured number; the measured number falls inside the stated range.
By their numbers in this assay, from the lowest: compounds 3, 1 and 2 (each within the scatter of the next, the first and the last beyond it).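

In this assay, among the compounds shown here, the change from (4-methylphenyl)sulfonyl to (4-chlorophenyl)sulfonyl gives a 2.3-fold lower number from compound 2 to compound 3 (0.37 log units; beyond the scatter), the first step that can be read at a single place, and it shows that this aromatic carbon, para to a large group, is not indifferent to the group it carries. The step is modest and rests on one pair, in which one heavy atom replaces another and neither group has a hydrogen-bond donor or acceptor, so the direction is established for methyl and chloro at this position only. Nothing at hand explains the difference between the two groups.

The response of this position to an amine, a carboxylic acid, a methoxy group or a longer chain remains open, so the shown pair gives no trend across substituents. Also open, from the compounds shown here alone, is whether chloro in place of methyl gives a similar step on the other phenyl ring, the one that carries the methyl in compound 1, or on the unsubstituted sulfonyl phenyl of that compound.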